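A Nitro Group Added to Compound 3

The source may report more compounds than this note shows. Statements on the series, on what has been measured and on what is new or still open speak of the compounds shown alone.

Within the data shown here, compound 3 `Cc1ccc(C(=O)CCc2nnc(-c3ccccc3)o2)c(C)c1` is one of three compounds measured in a functional assay on the whole organism (strain Wistar) for inhibition, with Rattus norvegicus as the target, with stated times of 30 min and 3 h, at a dose of 20 mg/kg by the oral route; on this read-out lower numbers stand for less inhibition and higher numbers for more inhibition at the one dose given (going by the name of the read-out). In this assay compound 3 gives 58%, the lowest of the three numbers, though its distance to the others stays within the scatter: compound 2 `Cc1ccc(C(=O)CCc2nnc(-c3ccc([N+](=O)[O-])cc3)o2)cc1` gives 60.5% and compound 1 `O=C(CCc1nnc(-c2ccc([N+](=O)[O-])cc2)o1)c1ccccc1` gives 62.7%. Among the measured compounds shown here, the one measured step between neighbours, a number 2.2 percentage points lower from compound 1 to compound 2 (within the scatter), is small.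

Compound 4 `Cc1ccc(C(=O)CCc2nnc(-c3ccc([N+](=O)[O-])cc3)o2)c(C)c1` differs from compound 3 in one place: nitro in place of hydrogen on an aromatic carbon. For the measured compounds named here, no measured step shows this exact change on its own. Compound 1 and compound 2, which both carry the nitro group, and compound 3, which does not, all sit within the scatter of one another, so there is no sign that the nitro group moves this read-out. Because the measured values of compound 1, compound 2 and compound 3 in this assay all fall close together, compound 4 is expected to follow them, with the estimated step of a number 2 percentage points higher from compound 3 to compound 4 (within the scatter) not beyond the scatter. Compound 4 is therefore estimated at 60%, in a range from 50% to 70%.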

Compound 4, a percentage reported as inhibition, in the whole organism at one dose (the size of the read-out at that dose, not a potency): 69.1%
For compound 4 the middle estimate is 9.1 percentage points below the measured one; low and high end bracket the measured number.
By their numbers in this assay, from the lowest: compounds 3, 2, 1 and 4 (each within the scatter of the next, the first and the last beyond it).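

In this assay the nitro group on this aromatic carbon, para to a large group, gives a clear change on the 2,4-dimethylphenyl compounds, with a number 11.1 percentage points higher from compound 3 to compound 4 (beyond the scatter) as the only step shown that lies beyond the scatter. The two other steps to compound 4, a number 8.6 percentage points higher from compound 2 to compound 4 (within the scatter) and a number 6.4 percentage points higher from compound 1 to compound 4 (within the scatter), stay within the scatter, so neither the added methyl nor the swap of phenyl for 2,4-dimethylphenyl has a clear effect on its own. Nothing available explains why the nitro step has this size.

Going by these compounds, whether an amine, a carboxylic acid or a chlorine atom in the same place would give a similar number remains open. Also open, on these data alone, is whether the nitro step has the same size when the other end of the molecule carries a plain phenyl.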